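A few compounds are considered here, and "the series" means these few. Any claim that something is new, unique, unknown or untested is made for them only; others in the source may bear on it.

Measured so far in an assay on isolated protein with Bile acid receptor (Homo sapiens) as the target; on this read-out higher numbers stand for an effect only at larger amounts of compound and lower numbers for an effect already at smaller amounts:
compound 1 `CCOc1cccc(-c2ccc(CN(C(=O)C3CCCCC3)c3cccc(/C=C/C(=O)OC)c3)cc2)c1`: 147 nM
compound 2 `COC(=O)/C=C/c1cccc(N(Cc2ccc(-c3cccc(C)c3)cc2)C(=O)C2CCCCC2)c1`: 109 nM

Going by the values given here, compound 2 stands lowest of these two numbers in this assay, but the only measured step, a 1.3-fold lower number from compound 1 to compound 2 (0.13 log units; within the scatter), is within the scatter, so the two compounds are not separated.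

Compound 3 `COC(=O)/C=C/c1cccc(N(Cc2ccc(-c3ccc(F)c(Cl)c3)cc2)C(=O)C2CCCCC2)c1` differs from compound 2 in one place: 3-chloro-4-fluorophenyl in place of 3-methylphenyl on an aromatic carbon. Among the compounds with values here, the single measured step, a 1.3-fold lower number from compound 1 to compound 2 (0.13 log units; within the scatter), also exchanges one group and stayed within the scatter, so no step beyond the scatter is expected here either. Compound 3 is expected near 100 nM, between 40 nM and 250 nM. The expected step, a 1.1-fold lower number from compound 2 to compound 3 (0.04 log units; within the scatter), is within the scatter.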

Compound 3, half-maximal effective concentration: 66 nM
Compound 3: middle estimate off by 1.5-fold (0.18 log units), on the high side, within the range that was stated.
By their numbers in this assay, from the lowest: compounds 3, 2 and 1 (each within the scatter of the next, the first and the last beyond it).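

In this assay, 3-chloro-4-fluorophenyl on this aromatic carbon, para to a large group, keeps the number in the range of 3-methylphenyl, with a 1.7-fold lower number from compound 2 to compound 3 (0.22 log units; within the scatter) leaving the two compounds unseparated. Going by these compounds alone, replacing 3-ethoxyphenyl with the same group gives a 2.2-fold lower number from compound 1 to compound 3 (0.35 log units; beyond the scatter) and is the only step so far that passes the scatter, though modestly. No evidence bears on the cause of either step. Still open, as far as these compounds go, is whether an amine or a carboxylic acid on this ring is accepted. From the compounds shown here alone, the effect of replacing the cyclohexyl carbonyl or the methyl ester also remains unknown.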